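Replacing 4-hydroxyphenyl in compound 2

The source may report more compounds than this note shows. Statements on the series, on what has been measured and on what is new or still open speak of the compounds shown alone.

In a functional assay on ECa-109 cells (Homo sapiens) for cytotoxicity, read by MTT assay, with a stated time of 48 h (on this read-out higher numbers stand for weaker inhibition and lower numbers for stronger inhibition), compound 1 (`COc1ccc(-c2c[nH]c(=O)n2-c2cc(OC)c(OC)c(OC)c2)cc1[N+](=O)[O-]`) gives > 50000 nM as a limit of the assay. Compound 2 (`COc1cc(NC(=O)n2cc(-c3ccc(O)cc3)n(-c3cc(OC)c(OC)c(OC)c3)c2=O)cc(OC)c1OC`) gives > 50000 nM as a limit too. Compound 2 thus stands at the limit of > 50000 nM in this assay, at which 2 of the 2 values shown sit, and has no number of its own. Compound 3 (`COc1ccc(-c2cn(C(=O)Nc3cc(OC)c(OC)c(OC)c3)c(=O)n2-c2cc(OC)c(OC)c(OC)c2)cc1N`) carries 3-amino-4-methoxyphenyl in place of 4-hydroxyphenyl on an aromatic carbon. Going by the values given here, no measured step covers this change, so the expected step of an at least 6.2-fold lower number from compound 2 to compound 3 (0.79 log units; beyond the scatter) is only a tentative gain in inhibition, and another limit remains possible. For compound 3 the estimate is 8000 nM with an expected range of 300 nM to 50000 nM in this assay for now.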

Compound 3, half-maximal inhibitory concentration: > 50000 nM
Compound 3 ended at the assay's limit; the forecaster's own chance of this, stated with the estimate: 35%; middle value at least 6.2-fold (0.79 log units) from the limit.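

Compound 2 and compound 3 both stand at a limit in this assay, so the step between them cannot be read. It remains open whether 3-amino-4-methoxyphenyl or 4-hydroxyphenyl gives stronger inhibition, since all compounds shown sit at one limit: the limit of > 50000 nM in this assay, at which 3 of the 3 values shown sit.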